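Swapping a difluorophenyl amide for a pyridyl amide

The source may report more compounds than this note shows. Statements on the series, on what has been measured and on what is new or still open speak of the compounds shown alone.

Measured so far in an ADME assay on LLC-MK2 cells (Macaca mulatta) for cytotoxicity, read by spectrophotometry and crystal violet staining, with a stated time of 4 days; a lower number here means that less compound is tolerated, a higher number that more compound is tolerated:
Compound 1 `CC(C)n1ncc2c(C(=O)Nc3c(F)cccc3F)cc(-c3cccs3)nc21` gives > 200000 nM, a limit of the assay rather than a number.
Compound 2 `CC(C)n1ncc2c(C(=O)Nc3ccccc3F)cc(-c3cncs3)nc21` gives 100000 nM.

Compound 1 therefore has no exact reading; what is known is only that it sits at the limit of > 200000 nM in this assay, at which 1 of the 2 values shown sits. That is the upper edge of what this assay can report, so compound 1 was tolerated up to the highest concentration tested. Compound 2 shows a number, and it lies close to that same edge.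

Compound 3 `CC(C)n1ncc2c(C(=O)Nc3cccnc3)cc(-c3cccs3)nc21` shares the core of compound 1 and differs in one place: pyridin-3-yl in place of 2,6-difluorophenyl on an amide-type nitrogen.

Among the compounds with values here, no measured pair shows what such a change does in this assay, so the step can only be judged from compound 1 itself. Since compound 1 is already at the limit, the expectation is that the step from compound 1 to compound 3 is small, a number no higher from compound 1 to compound 3 (the limit leaves the size open), with the outcome plausibly again a limit or a number near it. The estimated value for compound 3 is 200000 nM, expected to fall between 50000 nM and 400000 nM.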

Compound 3, half-maximal cytotoxic concentration: > 200000 nM
Compound 3: only a limit was reported; the forecaster's own chance of this, stated with the estimate: 50%; the middle value lies on the limit itself.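

In this assay compound 3 gives > 200000 nM, a limit of the assay and not a number. Compound 1 also reads only as a limit, so no size can be read for the step from one to the other: the limit of > 200000 nM in this assay, at which 2 of the 3 values shown sit.

Still open, going by these compounds, is whether pyridin-3-yl in place of 2,6-difluorophenyl on an amide-type nitrogen changes the tolerated concentration at all.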